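The source may hold more compounds than are shown below. What is called first, only, known or untested is meant among the compounds shown, and "the series" means these compounds.

Compound 1 `O=C(CCSc1nc2cc(Cl)ccc2o1)NC1CCCC1` carries a cyclopentylamino group on the carbonyl carbon of the shared core. In an ADME assay on microsomes from liver (Mus musculus) for metabolic stability, read by LC-MS, using NADPH, with a stated time of 45 min, tested at 0.5 uM (on this read-out lower numbers stand for slow clearance and higher numbers for fast clearance), compound 1 gives "not determined" (no result reported), so no number places it anywhere on the scale. Compound 2 `O=C(CCSc1nc2ccccc2o1)N1CCCC1` gives 161 mL/min/g in this assay. Compound 3 `CSc1nc2cc(Cl)ccc2o1` reaches only a limit of the assay in this assay, > 46.1 mL/min/g, which is the limit of > 46.1 mL/min/g in this assay, at which 1 of the 3 values shown sits. Compound 4 `CC1CCN(C(=O)CCSc2nc3cc(Cl)ccc3o2)C1` differs from compound 1 in one place (3-methylpyrrolidin-1-yl in place of cyclopentylamino on a carbonyl carbon). For the measured compounds named here, no step between measured compounds covers this change, so in this assay the shift is expected to be no larger than the usual scatter around the reading of compound 2. Compound 4 is therefore estimated at 150 mL/min/g, with an expected range from 60 mL/min/g to 400 mL/min/g.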

Compound 4, intrinsic clearance in a liver preparation (reported as CLH), per the amount of preparation that the assay uses: 90.7 mL/min/g
Compound 4: middle estimate off by 1.7-fold (0.22 log units), on the high side; the range from low to high includes it.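

No step to compound 4 can be read, as compound 1 gives "not determined" (no result reported) in this assay, and nothing shown bears on the reading of compound 4. The compounds shown leave open how cyclopentylamino and 3-methylpyrrolidin-1-yl compare on this read-out.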